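From Propoxy to Benzyloxy on an Ethyl Ester

The source may report more compounds than this note shows. Statements on the series, on what has been measured and on what is new or still open speak of the compounds shown alone.

Three close relatives of the unmeasured compound have results in a functional assay on the whole organism (strain Sprague-Dawley) for inhibition, with Rattus norvegicus as the target, with a stated time of 10 min; a lower number here means that less compound is needed, a higher number that more compound is needed for the effect. The free acid compound 1 `CCCOc1ccccc1-c1ncc(C(=O)O)c(=O)[nH]1` gives 0.9 mg/kg, and compound 2 `CCOc1ccc(C(=O)O)cc1-c1ncc(C(=O)O)c(=O)[nH]1`, which carries an ethoxy group and a second acid group, gives 25 mg/kg. The ethyl ester compound 3 `CCCOc1ccccc1-c1ncc(C(=O)OCC)c(=O)[nH]1` gives 5 mg/kg, so it sits between the other two, needing more than compound 1 and less than compound 2.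

Compound 4 `CCOC(=O)c1cnc(-c2ccccc2OCc2ccccc2)[nH]c1=O` keeps the ester of compound 3 and alters only the propoxy group: phenyl in place of ethyl on a saturated chain carbon bound to an oxygen on an aromatic ring. This exchange turns propoxy into benzyloxy.

Among the measured compounds shown here, the only measured change in one place, a 5.6-fold higher number from compound 1 to compound 3 (0.74 log units; beyond the scatter), is a modest step beyond the scatter, but it lies at the ester, not at this group. For the measured compounds named here, no measured step shows what this exchange does, so the data give no direction for it, and no shift beyond the scatter is expected. The estimated change, a 1.4-fold higher number from compound 3 to compound 4 (0.15 log units; within the scatter), is therefore small, with wide uncertainty. For compound 4 the expected value is 7 mg/kg, with an estimated range from 2 mg/kg to 25 mg/kg.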

Compound 4, dose for 50% inhibition: > 5 mg/kg
Compound 4 was reported as a limit; the forecaster's own chance of this, stated with the estimate: 10%; the middle value lies beyond the limit too.
By their numbers in this assay, from the lowest: compound 1; then compound 3; then compound 2.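

Replacing ethyl with phenyl on a saturated chain carbon bound to an oxygen on an aromatic ring turns propoxy into benzyloxy, and in this assay this gives a number no lower from compound 3 to compound 4 (the limit leaves the size open). Among the compounds shown here, this is the first reading at this position, as the earlier compounds differed in one place only at the ester. It shows that, on the ethyl ester, benzyloxy does not bring the number below that of propoxy, but the result for compound 4 is a limit, so the size of the change cannot be read: the limit of > 5 mg/kg in this assay, at which 1 of the 4 values shown sits.

Going by these compounds, whether benzyloxy would act in the same way on the free acid of compound 1 remains open, and so does the size of the effect of this exchange on either the ester or the acid. Also open, on these data alone, is how the number would respond to other groups at this place, such as a shorter methoxy group, or a propoxy chain ending in an amine or a carboxylic acid.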